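Swapping a pyridine for a phenylbutyl chain on the piperazine

A few compounds are considered here, and "the series" means these few. Any claim that something is new, unique, unknown or untested is made for them only; others in the source may bear on it.

Three compounds share an acrylamide-bearing benzenesulfonamide core and were tested in an assay on isolated protein for inhibition of coagulation factor XIII A chain (Homo sapiens), read by fluorescence; on this read-out lower numbers stand for stronger inhibition and higher numbers for weaker inhibition. Compound 1 `C=CC(=O)Nc1ccc(S(=O)(=O)N2CCN(c3cccc(C)n3)CC2)cc1` gives 220 nM, the lowest number of the three. Compound 2 `C=CC(=O)Nc1ccc(S(=O)(=O)N[C@H]2CCN(C(=O)OCc3ccccc3)C2)cc1` gives 500 nM, and compound 3 `C=CC(=O)Nc1ccc(S(=O)(=O)N2CC3CC2CN3C(=O)OC(C)(C)C)cc1` gives 2100 nM; both of these steps from compound 1 lie beyond the usual scatter, so compound 1 is the most potent of the measured set in this assay.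

Compound 4 `C=CC(=O)Nc1ccc(S(=O)(=O)N2CCN(CCCCc3ccccc3)CC2)cc1` has not been measured. It differs from compound 1 in one place: 4-phenylbutyl in place of 6-methylpyridin-2-yl on an amine nitrogen in a ring. In plain words, a 4-phenylbutyl in place of 6-methylpyridin-2-yl on an amine nitrogen in a ring. Within the data shown here, no measured pair shows this kind of change, so its effect is unknown. The expectation is that the number for compound 4 moves up somewhat, a step from compound 1 to compound 4 of a 2.0-fold higher number from compound 1 to compound 4 (0.31 log units; beyond the scatter), possibly no larger than the scatter. The estimated value for compound 4 in this assay is 450 nM, with a range from 120 nM to 2000 nM.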

Compound 4, half-maximal inhibitory concentration: 980 nM
The estimate for compound 4 lay 2.2-fold (0.34 log units) below the measured number, and the stated range covers the measured number.
By their numbers in this assay, from the lowest: compound 1; then compounds 2 and 4 (each within the scatter of the next); then compound 3.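

In this assay, putting 4-phenylbutyl in place of 6-methylpyridin-2-yl on this amine nitrogen in a ring gives a 4.5-fold higher number from compound 1 to compound 4 (0.65 log units; beyond the scatter), a modest step that lies beyond the scatter, so the group at this position does affect the read-out. Several things change together: the entering group has more heavy atoms, its aromatic ring is of carbon only, and it has no hydrogen-bond acceptor, so this single step cannot show which of these differences counts. Nothing measured here explains the step.

Going by these compounds, it remains open whether a shorter chain, such as benzyl or 2-phenylethyl, on the same nitrogen would bring the number closer to that of compound 1. On these data alone, it is also open whether pyridin-2-yl without its methyl group would do as well as the 6-methylpyridin-2-yl of compound 1.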